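Replacing hydroxy with methyl on the shared core

The source may report more compounds than this note shows. Statements on the series, on what has been measured and on what is new or still open speak of the compounds shown alone.

In a functional assay on SK-OV-3 cells (Homo sapiens) for inhibition, read by MTT assay (on this read-out lower numbers stand for stronger inhibition and higher numbers for weaker inhibition), compound 1 (`COc1ccc(/C=C2\c3cc(OC)c(OC)c(OC)c3CC[C@H]2O)cc1C#N`) gives 600 nM, compound 2 (`COc1ccc(/C=C2\c3cc(OC)c(OC)c(OC)c3CC[C@H]2O)cc1N`) gives 1870 nM and compound 3 (`COc1ccc(/C=C2\c3cc(OC)c(OC)c(OC)c3CC[C@H]2O)cc1O`) gives 1590 nM. Compound 3 therefore stands level with compound 2, at a 1.2-fold lower number from compound 2 to compound 3 (0.07 log units; within the scatter), and apart from compound 1, at a 2.7-fold higher number from compound 1 to compound 3 (0.42 log units; beyond the scatter). Compound 4 (`COc1ccc(/C=C2\c3cc(OC)c(OC)c(OC)c3CC[C@H]2O)cc1C`) has methyl in place of hydroxy on an aromatic carbon, ortho to a methoxy group: methyl in place of hydroxy on an aromatic carbon. Among the compounds with values here, no measured step makes this exact exchange. The closest evidence is the other exchanges at this carbon, including a 3.1-fold higher number from compound 1 to compound 2 (0.49 log units; beyond the scatter), and none is more than modest. A step no larger than modest is therefore expected in this assay, most likely within the scatter and with no firm direction. For compound 4 the estimated value is 1200 nM, with an expected range of 450 nM to 3000 nM. This estimate means an expected 1.3-fold lower number from compound 3 to compound 4 (0.12 log units; within the scatter).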

Compound 4, half-maximal inhibitory concentration: 1340 nM
Estimate against measurement, compound 4: 1.1-fold (0.05 log units) below; low and high end bracket the measured number.
By their numbers in this assay, from the lowest: compound 1; then compounds 4, 3 and 2 (each within the scatter of the next).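

In this assay, methyl, with 0 hydrogen-bond donors and 0 hydrogen-bond acceptors, stays level with both hydroxy and amino at this aromatic carbon, with a 1.2-fold lower number from compound 3 to compound 4 (0.07 log units; within the scatter) and a 1.4-fold lower number from compound 2 to compound 4 (0.14 log units; within the scatter). Nitrile alone stands apart among the four groups, with a 2.2-fold higher number from compound 1 to compound 4 (0.35 log units; beyond the scatter). No available evidence accounts for this result. As far as these compounds go, whether other groups at this carbon, such as a carboxylic acid, a chlorine atom or an ethyl chain, would match the nitrile of compound 1 or stay level with compound 4 remains open.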